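The source may hold more compounds than are shown below. What is called first, only, known or untested is meant among the compounds shown, and "the series" means these compounds.

Measured so far in a functional assay on HepG2 cells (Homo sapiens) for cytotoxicity, read by MTT assay, with a stated time of 72 h; on this read-out higher numbers stand for weaker inhibition and lower numbers for stronger inhibition:

- compound 1, `CNC(=O)c1cc(Oc2ccc(C(=O)/C=C/c3cc(OC)c(OC)c(OC)c3)cc2)ccn1`, gives 560 nM.
- compound 2, `CNC(=O)c1cc(Oc2ccc(/C=C/C(=O)c3ccc(C)cc3)cc2)ccn1`, gives only a limit of the assay, > 50000 nM.
- compound 3, `CNC(=O)c1cc(Oc2ccc(C(=O)/C=C/c3ccc(F)cc3)cc2)ccn1`, gives 12600 nM.

All three share one core, with a carbonyl-linked double-bonded chain carrying a varied phenyl ring. Compound 3 stands at the highest of the two numbers that were actually reached; compound 1 sits well below it, a gap beyond the usual scatter. Compound 2 reached only a limit, so no number stands for it.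

The next compound, compound 4, `CNC(=O)c1cc(Oc2ccc(C(=O)/C=C/c3ccc(Cl)c(Cl)c3)cc2)ccn1`, differs from compound 3 in one place: 3,4-dichlorophenyl in place of 4-fluorophenyl on a double-bonded chain carbon bound to a double-bonded chain carbon. Among the measured compounds shown here, no measured pair shows this change, so its effect has to be guessed. Two chlorines in place of one fluorine on the same ring is a modest change in shape, and nothing among compounds 1, 2 and 3 points to a direction for it, so the step from compound 3 is expected to be small, within or just beyond the scatter, with a slight lean toward a lower number. On that basis the expected step is a 1.6-fold lower number from compound 3 to compound 4 (0.20 log units; within the scatter), and compound 4 is estimated at 8000 nM, with a range from 2000 nM to 30000 nM.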

Compound 4, half-maximal inhibitory concentration: 11400 nM
The estimate for compound 4 lay 1.4-fold (0.15 log units) below the measured number, and the stated range covers the measured number.
By their numbers in this assay, from the lowest: compound 1; then compounds 4 and 3 (each within the scatter of the next). At a limit, above all of these: compound 2.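

Among the compounds shown here, at a double-bonded chain carbon bound to a double-bonded chain carbon, putting 3,4-dichlorophenyl in place of 4-fluorophenyl gives in this assay a 1.1-fold lower number from compound 3 to compound 4 (0.04 log units; within the scatter) and is the first single change at this place that can be read as a step. Two chlorines on the ring in place of one fluorine therefore leave the number where it was, so this particular change does not separate the two compounds, even though the ring gains a heavy atom and loses none of its aromatic carbon; the much lower number of compound 1, at 560 nM, shows that a change of ring here need not always be this silent. No measurement shown bears on the reason for this flat result.

The compounds shown leave open whether a ring with a single chlorine in place of the fluorine would read any differently from the two chlorines of compound 4. They also leave open whether a phenyl ring carrying an amine or a carboxylic acid at this place would move the number toward that of compound 1 or away from it.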